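The source may report more compounds than this note shows. Statements on the series, on what has been measured and on what is new or still open speak of the compounds shown alone.

Working notes on the series. In a functional assay on RS4-11 cells (Homo sapiens) for inhibition, read by CCK-8 assay, with a stated time of 48 h (a higher number here means a weaker inhibitor, a lower number a stronger inhibitor), compound 1 `Cc1cc(C)cc(NC(=O)NCCNS(=O)(=O)c2ccc(-c3ccccc3Oc3ccc([N+](=O)[O-])c([N+](=O)[O-])c3)s2)c1` gives 3600 nM and compound 3 `O=C(NCCNS(=O)(=O)c1ccc(-c2ccccc2Oc2ccc([N+](=O)[O-])c([N+](=O)[O-])c2)s1)Nc1ccc([N+](=O)[O-])cc1` gives 3000 nM. These two values lie within the scatter of each other, so compound 3 stands level with compound 1. Compound 2 `COc1cccc(NC(=O)NCCNS(=O)(=O)c2ccc(-c3ccccc3OCc3ccccc3)s2)c1` reads > 20000 nM, which is a limit of the assay and not a number.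

The next step goes from compound 3 to compound 4 `COc1cccc(NC(=O)NCCNS(=O)(=O)c2ccc(-c3ccccc3Oc3ccc([N+](=O)[O-])c([N+](=O)[O-])c3)s2)c1`, with 3-methoxyphenyl in place of 4-nitrophenyl on an amide-type nitrogen. The shared core stays unchanged.

Among the compounds with values here, one measured step bears on this change. With 4-nitrophenyl in place of 3,5-dimethylphenyl on an amide-type nitrogen, the result was a 1.2-fold lower number from compound 1 to compound 3 (0.08 log units; within the scatter). Within the data shown here, that single step is the only guide at this nitrogen, and it stayed within the scatter. No shift beyond the scatter is therefore expected in this assay, and no direction is favoured.

The expected step is a 1.2-fold higher number from compound 3 to compound 4 (0.07 log units; within the scatter). The estimated value for compound 4 is 3500 nM, with an expected range from 1500 nM to 9000 nM.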

Compound 4, half-maximal inhibitory concentration: 1300 nM
Compound 4: middle estimate off by 2.7-fold (0.43 log units), on the high side; the whole stated range lies above it.
By their numbers in this assay, from the lowest: compound 4; then compounds 3 and 1 (each within the scatter of the next). At a limit, above all of these: compound 2.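

In this assay, the amide-type nitrogen proves able to move the number: where the earlier step stayed within the scatter, 3-methoxyphenyl gives a 2.3-fold lower number from compound 3 to compound 4 (0.36 log units; beyond the scatter) and a 2.8-fold lower number from compound 1 to compound 4 (0.44 log units; beyond the scatter), which makes compound 4 the strongest inhibitor of the four shown. The change on the oxygen is labelled large rather than modest: with 3-methoxyphenyl held on the amide-type nitrogen, 3,4-dinitrophenyl in place of benzyl on an oxygen on an aromatic ring gives an at least 15-fold lower number from compound 2 to compound 4 (1.18 log units; beyond the scatter). Compound 2 reads as a limit and not a number, so the full size of that step cannot be fixed: the limit of > 20000 nM in this assay, at which 1 of the 4 values shown sits.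

Within the data shown here, the step on the oxygen is read with only one group on the amide-type nitrogen, so whether it holds the same size with 4-nitrophenyl or 3,5-dimethylphenyl there stays open. Also open, from the compounds shown here alone, is whether the lower number belongs to the methoxy group itself, which a phenyl ring carrying an ethoxy group, an amine or a carboxylic acid in its place would test.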